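Swapping a 4-ethoxyphenyl for a 4-chlorobenzyl on a fused core

The source may hold more compounds than are shown below. What is called first, only, known or untested is meant among the compounds shown, and "the series" means these compounds.

Measured compounds and their values:
Compound 1 `COc1ccc(-c2nn3cc(-c4cccc(N)c4)nc3s2)cc1OC` gives 26000 nM.
Compound 2 `C=C(Br)C(=O)Nc1cccc(-c2cn3nc(-c4ccc(OCC)cc4)sc3n2)c1` gives 1100 nM.
Compound 3 `C=C(Br)C(=O)Nc1cccc(-c2cn3c(-c4ccccc4)csc3n2)c1` gives 3400 nM.

These values come from a functional assay on HeLa cells (Homo sapiens) for inhibition, read by cell counting, with a stated time of 4 days; on this read-out lower numbers stand for stronger inhibition and higher numbers for weaker inhibition. Compound 2 stands lowest of the three numbers, so it is the strongest inhibitor in this set. Its nearest neighbour is compound 3, whose number is higher by an amount beyond the usual scatter. Compound 1 sits far away, with a much higher number, again well beyond the scatter.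

The next step leads from compound 2 to compound 4 `C=C(Br)C(=O)Nc1cccc(-c2cn3nc(Cc4ccc(Cl)cc4)sc3n2)c1`, which has not yet been measured in this assay. The change is 4-chlorobenzyl in place of 4-ethoxyphenyl on an aromatic carbon. Among the compounds with values here, no pair of measured compounds differs in one place, so no measured step is available to calibrate this change, and the expectation rests on compound 2 alone.

Because compound 2 gives 1100 nM, compound 4 is expected to land near it, most likely a little weaker, with a step of a 2.3-fold higher number from compound 2 to compound 4 (0.36 log units; beyond the scatter) that may reach beyond the scatter. The estimate for compound 4 is 2500 nM, within a range from 800 nM to 8000 nM.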

Compound 4, half-maximal inhibitory concentration: 2700 nM
Beside the measured number, compound 4's estimate is 1.1-fold (0.03 log units) below it; the range from low to high includes it.
By their numbers in this assay, from the lowest: compound 2; then compounds 4 and 3 (each within the scatter of the next); then compound 1.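

In this assay, within the data shown here, 4-chlorobenzyl in place of 4-ethoxyphenyl gives a 2.5-fold higher number from compound 2 to compound 4 (0.39 log units; beyond the scatter), the first change in this set that can be read at a single place. That place is an aromatic carbon of the five-membered aromatic ring with 2 nitrogen and 1 sulfur, next to the ring nitrogen and next to the ring sulfur, and the step shows that inhibition there responds to the group it carries, though only modestly for this swap. The swap changes several things at once, taking away an oxygen and bringing in a chlorine, and nothing available shows which of these changes matters or why the number rises.

As far as these compounds go, a plain benzyl or a 4-chlorophenyl group at this carbon would pull those parts of the swap apart, and whether either would read closer to compound 2 or to compound 4 remains open. How an amine or a carboxylic acid on the same carbon would behave in this assay also remains an open question.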